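The compounds below may be only part of what the source reports. "The series", "measured", "known", "first", "only" and "open" are said of these compounds alone.

Compound 1, `O=C(NC1CCN(Cc2ccc(OC3CCNCC3)c(Br)c2)CC1)c1cc2ccccc2s1`, gives 63 nM in an assay on HEK293 cells for displacement of a labelled ligand from Urotensin-2 receptor (Homo sapiens), read by fluorescence, with a stated time of 90 min; a lower number here means a stronger inhibitor, a higher number a weaker inhibitor.
Compound 2, `N#Cc1ccc2cc(C(=O)NC3CCN(Cc4ccc(OC5CCNCC5)c(Br)c4)CC3)sc2c1`, gives 80 nM.
Compound 3, `Cc1ccc2sc(C(=O)NC3CCN(Cc4ccc(OC5CCNCC5)c(Br)c4)CC3)cc2c1`, gives 74 nM.

Compound 3 has the second highest of these three numbers, but the gaps are tiny: a 1.1-fold lower number from compound 2 to compound 3 (0.03 log units; within the scatter), and the step to compound 1 is equally small, so the three cannot be told apart. Compound 4, `COc1ccc2sc(C(=O)NC3CCN(Cc4ccc(OC5CCNCC5)c(Br)c4)CC3)cc2c1`, arises from compound 3 by methoxy in place of methyl on an aromatic carbon. Within the data shown here, no measured step swaps one group for another at this carbon; the closest guides are the step that introduced the methyl, a 1.2-fold higher number from compound 1 to compound 3 (0.07 log units; within the scatter), and the step that added a nitrile to the same core, a 1.3-fold higher number from compound 1 to compound 2 (0.10 log units; within the scatter), both within the scatter. The estimated step is therefore modest, a 1.1-fold higher number from compound 3 to compound 4 (0.06 log units; within the scatter). Compound 4 is expected to give about 85 nM, within a range of 35 nM to 200 nM.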

Compound 4, half-maximal inhibitory concentration: 100 nM
The estimate for compound 4 lay 1.2-fold (0.07 log units) below the measured number; the measured number falls inside the stated range.
By their numbers in this assay, from the lowest: compounds 1, 3, 2 and 4 (each within the scatter of the next).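

Methoxy, with its hydrogen-bond acceptor, can replace methyl on this aromatic carbon with no change that can be told from the scatter (a 1.4-fold higher number from compound 3 to compound 4 (0.13 log units; within the scatter)), and the same holds for methoxy in place of hydrogen, the largest step so far (a 1.6-fold higher number from compound 1 to compound 4 (0.20 log units; within the scatter)). The step from the 6-cyano-1-benzothiophen-2-yl group to the 5-methoxy-1-benzothiophen-2-yl group is also within the scatter (a 1.3-fold higher number from compound 2 to compound 4 (0.10 log units; within the scatter)), so all four compounds remain indistinguishable. No measurement at hand offers an explanation for this result. As far as these compounds go, whether an amine or a carboxylic acid on this carbon would give a number beyond the scatter remains open.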